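Halogen swap on the phenyl group: compound 3 to compound 4

The compounds below may be only part of what the source reports. "The series", "measured", "known", "first", "only" and "open" are said of these compounds alone.

Measured compounds in a functional assay on U-87MG ATCC cells for antiproliferative activity against U-87 MG (Homo sapiens), read by MTT assay, with a stated time of 72 h; on this read-out higher numbers stand for weaker inhibition and lower numbers for stronger inhibition:
- compound 1 `CNC(=O)c1cc(Oc2ccc(NC(=O)c3cc4cccnc4n(-c4ccccc4)c3=O)cc2)ccn1`: 1820 nM
- compound 2 `CNC(=O)c1cc(Oc2ccc(NC(=O)c3cc4cccnc4n(-c4ccccc4F)c3=O)cc2)ccn1`: 3360 nM
- compound 3 `CNC(=O)c1cc(Oc2ccc(NC(=O)c3cc4cccnc4n(-c4ccc(Cl)cc4)c3=O)cc2)ccn1`: "not determined" (no result reported)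

Compound 3 carries a chloro group on the phenyl attached to the shared core and stands without a number in this assay; where it lies relative to compound 1 and compound 2 is therefore unknown. Compound 4 `CNC(=O)c1cc(Oc2ccc(NC(=O)c3cc4cccnc4n(-c4ccc(Br)cc4)c3=O)cc2)ccn1` differs from compound 3 by bromo in place of chloro on an aromatic carbon.

Going by the values given here, the only measured step on that phenyl is a 1.8-fold higher number from compound 1 to compound 2 (0.27 log units; within the scatter), a change that stayed within the scatter. Among the compounds with values here, no measured pair shows a chloro-to-bromo exchange, so the step from compound 3 to compound 4 in this assay cannot be sized from a directly comparable step. Taking the fluoro step as the nearest guide, no step beyond the scatter in either direction is expected from this exchange. With compound 3 unmeasured, the expectation for compound 4 rests on compound 1 and compound 2. Compound 4 is estimated at 2500 nM in this assay, within a range of 900 nM to 7000 nM.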

Compound 4, half-maximal inhibitory concentration: 15000 nM
Compound 4: the middle estimate sits 6.0-fold (0.78 log units) below what was measured, outside the stated range (above it).
By their numbers in this assay, from the lowest: compounds 1 and 2 (each within the scatter of the next); then compound 4.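

In this assay the phenyl on the shared core now gives a step beyond the scatter: bromo in place of hydrogen produces an 8.2-fold higher number from compound 1 to compound 4 (0.92 log units; beyond the scatter) and so weaker inhibition. The 4-bromophenyl also stands apart from the 2-fluorophenyl, with a 4.5-fold higher number from compound 2 to compound 4 (0.65 log units; beyond the scatter), whereas the fluoro step alone stayed within the scatter. The step from compound 3 to compound 4 cannot be read, as compound 3 has no number, and no measurement offered here explains the weaker inhibition of compound 4.

Open, from the compounds shown here alone, is whether this loss is specific to bromo or follows from any 4-substituent on this phenyl, as the 4-chlorophenyl gives no comparison. Also open, going by these compounds, is how a methoxy group, an amine or a carboxylic acid at the same place would read out.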